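Stripping Benzyl Groups from a Sugar-Like Antiproliferative Scaffold

This account rests on a few compounds, and the source may have more. Where it says the series, first, only, none or still open, it means among the compounds named here.

Measured compounds:
Compound 1, `O[C@@H]1[C@@H](OCc2ccccc2)[C@H](OCc2ccccc2)[C@@H](COCc2ccccc2)O[C@H]1Cc1ccccc1`, gives 8700 nM.
Compound 2, `OC[C@H]1O[C@@H](Cc2ccccc2)[C@H](O)[C@@H](O)[C@@H]1O`, gives "not active" (no number reported).
Compound 3, `CCC[C@@H]1O[C@H](COCc2ccccc2)[C@@H](OCc2ccccc2)[C@H](OCc2ccccc2)[C@H]1O`, gives 11700 nM.

All three were tested in a functional assay on HL-60 cells (Homo sapiens) for antiproliferative activity, read by MTT assay; a higher number here means a weaker inhibitor, a lower number a stronger inhibitor. Compound 1 and compound 3 share a core carrying three benzyl ether groups; the difference between them is ethyl in place of phenyl on a saturated chain carbon bound to a saturated ring carbon. This change gave a 1.3-fold higher number from compound 1 to compound 3 (0.13 log units; within the scatter), so the two compounds cannot be told apart by this measurement.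

Compound 2 is the same framework with the benzyl ethers removed, leaving free hydroxyl groups; the difference between its core and that of compound 1 is not broken down here. Compound 2 showed no measurable inhibition in this assay, so no number is available for it.

Compound 4, `CCC[C@@H]1O[C@H](CO)[C@@H](O)[C@H](O)[C@H]1O`, is not yet measured. It stands to compound 2 as compound 3 stands to compound 1: the difference is ethyl in place of phenyl on a saturated chain carbon bound to a saturated ring carbon, the same change at the same place. In the benzylated pair the change produced no effect beyond the scatter, as seen in a 1.3-fold higher number from compound 1 to compound 3 (0.13 log units; within the scatter); an equally small step is expected from compound 2 to compound 4 in this assay. Since compound 2 itself gave no number, compound 4 is expected to be weak or inactive as well, with an estimated value around 60000 nM, and expected to lie between 15000 nM and 250000 nM.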

Compound 4, half-maximal inhibitory concentration: "not active" (no number reported)
For compound 4 the study gives words and no number, and the estimate cannot be compared.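

Compound 2 and compound 4 both came back from this assay as not active, without a number, so no step can be read between them. What the compounds shown leave open is whether ethyl in place of phenyl makes any difference at all on this core with free hydroxyl groups. No measured evidence bears on this result.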